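Para-substituent swap on the shared core

A few compounds are considered here, and "the series" means these few. Any claim that something is new, unique, unknown or untested is made for them only; others in the source may bear on it.

Compound 3 `Fc1ccc(-c2cn3ccnc3c(-c3ccc4ncn(C5CCCCC5)c4c3)n2)cc1` stands second highest of the three numbers recorded in a functional assay on OVCAR-3 cells (Homo sapiens) for inhibition, read by sulforhodamine B assay, with a stated time of 48 h, tested at 10 uM; a lower number here means less inhibition, a higher number more inhibition at the concentration tested (going by the name of the read-out): compound 3 gives 7.88%. Its nearest neighbour is compound 1 `Brc1cn2ccnc2c(-c2ccc3ncn(C4CCCCC4)c3c2)n1`, which in this assay gives 15.8%; the gap a number 7.9 percentage points lower from compound 1 to compound 3 (within the scatter) lies within the scatter. Furthest off is compound 2 `COc1ccc(-c2cn3ccnc3c(-c3ccc4ncn(C5CCCCC5)c4c3)n2)cc1`, which in this assay gives -26.5%.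

Compound 4 `Clc1ccc(-c2cn3ccnc3c(-c3ccc4ncn(C5CCCCC5)c4c3)n2)cc1` differs from compound 3 by a single change: chloro in place of fluoro on an aromatic carbon.

The measured step that bears most directly on this change is the swap of one group on that same six-membered ring, a number 34.4 percentage points higher from compound 2 to compound 3 (beyond the scatter), a large move. The other step onto compound 3, a number 7.9 percentage points lower from compound 1 to compound 3 (within the scatter), exchanged bromo for the whole 4-fluorophenyl and stayed within the scatter. No exchange of one single-atom group for another on that ring has yet been measured, so no direction can be read from the series. The expected step of a number 2.1 percentage points higher from compound 3 to compound 4 (within the scatter) is therefore one within the scatter. Compound 4 is estimated at 10%, with a range from -15% to 35%.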

Compound 4, a percentage reported as inhibition, at one concentration (the size of the read-out at that concentration, not a potency): 10.9%
The estimate for compound 4 lay 0.9 percentage points below the measured number; low and high end bracket the measured number.
By their numbers in this assay, from the lowest: compound 2; then compounds 3, 4 and 1 (each within the scatter of the next).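

In this assay, for the compounds shown here, this is the first exchange of one single-atom group for another on this ring, and a number 3 percentage points higher from compound 3 to compound 4 (within the scatter) shows no separation between fluoro and chloro at this place. Chloro also sits far from methoxy, with a number 37.4 percentage points higher from compound 2 to compound 4 (beyond the scatter), while a number 4.9 percentage points lower from compound 1 to compound 4 (within the scatter) leaves 4-chlorophenyl unseparated from bromo on the core, so among these four compounds only compound 2 stands apart. Nothing available on the mechanism bears on this result.

The compounds shown leave open whether the low number belongs to methoxy alone or also extends to hydroxy or ethoxy at this place. From the compounds shown here alone, whether a dimethylamino or carboxylic acid group on the same carbon would move the number as far as methoxy does also remains open.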